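Trifluoromethylphenyl to Difluorophenyl: Expected Clearance of Compound 3

The source may report more compounds than this note shows. Statements on the series, on what has been measured and on what is new or still open speak of the compounds shown alone.

Compound 1 `O=S(=O)(CC1CC1)c1nnc(-c2cc(F)c(-c3cnc(Oc4ccccc4C(F)(F)F)c(Cl)c3)cc2F)[nH]1`: < 14 uL/min
Compound 2 `COc1cc(-c2nnc(S(=O)(=O)C3CCC3)[nH]2)ccc1-c1cnc(OCC(C)C)c(Cl)c1`: 59 uL/min

Both compounds were tested in an ADME assay on microsomes from liver (Homo sapiens) for metabolic stability; a lower number here means slower removal, a higher number faster removal of the compound. Compound 1 returns only a limit of the assay, < 14 uL/min, which is the limit of < 14 uL/min in this assay, at which 1 of the 2 values shown sits. Compound 2 gives a number, 59 uL/min. Compound 3 `O=S(=O)(CC1CC1)c1nnc(-c2cc(F)c(-c3cnc(Oc4ccc(F)cc4F)c(Cl)c3)cc2F)[nH]1` is not yet measured; it differs from compound 1 in one place: 2,4-difluorophenyl in place of 2-(trifluoromethyl)phenyl on an oxygen on an aromatic ring. Among the measured compounds shown here, no measured pair shows this change, so its size is not known from these data. In this assay the step of a number no lower from compound 1 to compound 3 (the limit leaves the size open) is expected to be small, within the scatter or a slight rise. Compound 3 is therefore estimated at 14 uL/min, with a range from 7 uL/min to 30 uL/min.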

Compound 3, intrinsic clearance in a liver preparation (reported as CLH), per the amount of preparation that the assay uses: < 14 uL/min
Compound 3 was reported as a limit (the forecaster's own chance of this, stated with the estimate: 50%); the middle value sits exactly at the limit.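

Among the compounds shown here, no step from compound 1 to compound 3 can be read in this assay, because both compounds return only a limit of the assay: the limit of < 14 uL/min in this assay, at which 2 of the 3 values shown sit. The compounds shown leave open whether 2,4-difluorophenyl in place of 2-(trifluoromethyl)phenyl changes the rate of removal at all.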